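The source may hold more compounds than are shown below. What is called first, only, known or untested is meant among the compounds shown, and "the series" means these compounds.

Three measured compounds share one core. Compound 1 `CCCN(Cc1ccccc1)c1nc(C)nc(Nc2ccc(C)cc2)n1` carries a propyl chain beside the benzyl group on its chain nitrogen. In an assay on isolated protein for binding affinity to corticotropin-releasing factor receptor 1 (Homo sapiens) (a higher number here means a weaker inhibitor, a lower number a stronger inhibitor), compound 1 gives > 10000 nM, which is a limit of the assay and not a number. Compound 2 `C=CCN(CC=C)c1nc(C)nc(Nc2ccc(C)cc2)n1` bears two allyl groups on that nitrogen. In this assay compound 2 gives > 10000 nM, again a limit. Compound 3 `CCN(Cc1ccccc1)c1nc(C)nc(Nc2ccc(C)cc2)n1` has an ethyl chain in place of the propyl of compound 1. In this assay compound 3 gives > 10000 nM, a limit once more. Compound 3 therefore stands at the limit of > 10000 nM in this assay, at which 3 of the 3 values shown sit, together with every other measured compound. The step that the two limits leave unreadable from compound 1 to compound 3 cannot be read, since both ends of it are limits.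

Compound 4 `CCN(Cc1ccccc1)c1nc(C)nc(Nc2c(C)cc(C)cc2C)n1` is not yet measured. It differs from compound 3 by 2,4,6-trimethylphenyl in place of 4-methylphenyl on a nitrogen on an aromatic ring. Among the compounds with values here, no measured step bears on this change, and the only measured step, from compound 1 to compound 3, is of unreadable size. The account therefore rests on no measured direction at all. The authors' view is that compound 4 is expected to move toward stronger binding than the limit of compound 3, by an estimated step of an at least 16-fold lower number from compound 3 to compound 4 (1.22 log units; beyond the scatter). Compound 4 is estimated at 600 nM, in the range 30 nM to 10000 nM.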

Compound 4, inhibition constant: 1470 nM
The estimate for compound 4 lay 2.5-fold (0.39 log units) below the measured number, within the range that was stated.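

In this assay, as far as these compounds go, the replacement of 4-methylphenyl by 2,4,6-trimethylphenyl on a nitrogen on an aromatic ring gives the series its first step that can be read, an at least 6.8-fold lower number from compound 3 to compound 4 (0.83 log units; beyond the scatter), and that step lies beyond the scatter, although its full size stays open since its starting point is a limit. The earlier compounds shown here differ only in the groups on the chain nitrogen, and the steps among them cannot be read, so they showed nothing about the aryl group on the other nitrogen, which now proves able to shift binding. Compound 4 is the only compound shown that carries a number and not a limit: the limit of > 10000 nM in this assay, at which 3 of the 4 values shown sit.

The compounds shown leave open which of the added methyl groups on the ring accounts for the step, and whether a methoxy group or a chlorine in their place would serve as well. They also leave open how the propyl chain of compound 1, or the two allyl groups of compound 2, would read together with 2,4,6-trimethylphenyl.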